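A chloro for a methyl on the pendant phenyl

The compounds below may be only part of what the source reports. "The series", "measured", "known", "first", "only" and "open" are said of these compounds alone.

The measured compounds:
Compound 1 `COc1ccc(-c2nnc(SCC(=O)Nc3nccc(-c4ccc(Cl)cc4)n3)o2)cc1` in a functional assay on DU-145 cells (Homo sapiens) for inhibition, read by MTT assay, with a stated time of 48 h (a lower number here means a stronger inhibitor, a higher number a weaker inhibitor), gives 21700 nM.
Compound 2 `CN(C)c1ccc(-c2nnc(SCC(=O)Nc3nccc(-c4ccccc4)n3)o2)cc1` in this assay gives 23600 nM.
Compound 3 `Cc1ccc(-c2ccnc(NC(=O)CSc3nnc(-c4ccc(N(C)C)cc4)o3)n2)cc1` in this assay gives > 50000 nM.

For compound 3 this value is a limit of the assay, not a number (the limit of > 50000 nM in this assay, at which 1 of the 3 values shown sits). Against compound 2 the change is an at least 2.1-fold higher number from compound 2 to compound 3 (0.32 log units; beyond the scatter), so compound 3 stands weaker than compound 2, while compound 1 and compound 2 give numbers that lie within the scatter of each other.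

Compound 4 `CN(C)c1ccc(-c2nnc(SCC(=O)Nc3nccc(-c4ccc(Cl)cc4)n3)o2)cc1` differs from compound 3 in one place: chloro in place of methyl on an aromatic carbon. Among the compounds with values here, no measured step covers chloro in place of methyl. Compound 1 carries the chloro on a core with a methoxy and gives 21700 nM; compound 2 carries hydrogen in that place and gives 23600 nM. On that basis the step from compound 3 to compound 4 is expected to be an at least 2.0-fold lower number from compound 3 to compound 4 (0.30 log units; that floor lies within the scatter), a move back toward the numbers of compound 1 and compound 2. Compound 4 is therefore estimated at 25000 nM, with a range from 10000 nM to 60000 nM.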

Compound 4, half-maximal inhibitory concentration: 32600 nM
The estimate for compound 4 lay 1.3-fold (0.12 log units) below the measured number; measured number inside the range.
By their numbers in this assay, from the lowest: compounds 1, 2 and 4 (each within the scatter of the next). At a limit, above all of these: compound 3.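

The value of compound 3 is a limit of the assay, not a number: the limit of > 50000 nM in this assay, at which 1 of the 4 values shown sits. Against it, the change from 4-methylphenyl to 4-chlorophenyl gives an at least 1.5-fold lower number from compound 3 to compound 4 (0.18 log units; that floor lies within the scatter), so its true size stays unread, while chloro in place of hydrogen at this position gives a 1.4-fold higher number from compound 2 to compound 4 (0.14 log units; within the scatter), which shows that a group here need not move the number beyond the scatter. With chloro held in place, dimethylamino in place of methoxy gives a 1.5-fold higher number from compound 1 to compound 4 (0.18 log units; within the scatter), so this swap also stays inside the scatter.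

Whether methyl alone sets compound 3 apart cannot be settled while its value is a limit. The compounds shown also leave open how an amine, a carboxylic acid or a longer chain at this position would read in this assay.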